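A few compounds are considered here, and "the series" means these few. Any claim that something is new, unique, unknown or untested is made for them only; others in the source may bear on it.

Measured compounds in a functional assay on HepG2 cells (Homo sapiens) for cytotoxicity, read by MTT assay; a lower number here means that less compound is tolerated, a higher number that more compound is tolerated:

Compound 1, `Nc1cn(COCCO)c(=O)[nH]c1=O`. In this assay compound 1 gives only a limit, > 497000 nM.
Compound 2, `CCc1cn(COCCO)c(=S)[nH]c1=O`. In this assay compound 2 gives only a limit, > 478000 nM.
Compound 3, `O=c1ccn(COCCO)c(=S)[nH]1`. In this assay compound 3 gives only a limit, > 495000 nM.

Compound 3 therefore stands nowhere on a scale: its result is a limit, and the two further values shown are limits as well (the limit of > 478000 nM in this assay, at which 1 of the 3 values shown sits, (the limit of > 497000 nM in this assay, at which 1 of the 3 values shown sits)). Within the data shown here, the one step measured, a step that the two limits leave unreadable from compound 2 to compound 3, cannot be read for size, since both ends of it are limits (the limit of > 495000 nM in this assay, at which 1 of the 3 values shown sits).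

Compound 4, `CCOC(=O)c1cn(COCCO)c(=S)[nH]c1=O`, differs from compound 3 by ethoxycarbonyl in place of hydrogen on an aromatic carbon. Among the measured compounds shown here, no measured step touches this change, and the one step that reaches compound 3 is itself unreadable. The only basis for an expectation is that all three values shown sit at limits; a fourth limit in this assay is thus expected, and no direction or size of change can be given.

The step from compound 3 to compound 4 is estimated at an at least 1.0-fold lower number from compound 3 to compound 4 (0.01 log units; that floor lies within the scatter). In this assay compound 4 is expected to give 480000 nM, within 150000 nM to 1500000 nM.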

Compound 4, half-maximal cytotoxic concentration: > 364000 nM
Compound 4 gave a limit, no number; the forecaster's own chance of this, stated with the estimate: 85%; the middle value does not contradict the limit.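

In this assay compound 4 gives only a limit, so the steps to it from compound 3 and from compound 2 cannot be read for size. The compounds shown leave open whether any group at this place on the shared core yields a measurable half-maximal cytotoxic concentration.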